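Adding a Methoxy Group to the Phenyl of Compound 1

A few compounds are considered here, and "the series" means these few. Any claim that something is new, unique, unknown or untested is made for them only; others in the source may bear on it.

Measured compounds:
compound 1 `COc1cc(-n2c(-c3ccccc3)csc2=S)cc(OC)c1OC` — 52 ug/mL
compound 2 `COc1cc(-n2c(-c3ccc(O)c(O)c3)csc2=S)cc(OC)c1OC` — 29.8 ug/mL

Of the compounds shown here, two sharing a core have been tested in a functional assay on MDA-MB-231 cells (Homo sapiens) for cytotoxicity, read by MTT assay, with a stated time of 48 h; a higher number here means a weaker inhibitor, a lower number a stronger inhibitor. Compound 1 gives 52 ug/mL, and compound 2 gives 29.8 ug/mL. The two numbers lie within the usual scatter of each other, as the step of a 1.7-fold lower number from compound 1 to compound 2 (0.24 log units; within the scatter) shows, so neither compound can be called the stronger inhibitor on these data.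

Compound 3 `COc1ccc(-c2csc(=S)n2-c2cc(OC)c(OC)c(OC)c2)cc1` differs from compound 1 by methoxy in place of hydrogen on an aromatic carbon. Within the data shown here, the only measured step that alters the same phenyl ring is a 1.7-fold lower number from compound 1 to compound 2 (0.24 log units; within the scatter), and it stayed within the scatter. With nothing else to go on, no step beyond the scatter is expected for compound 3 in this assay. Compound 3 is therefore estimated to give about 45 ug/mL, with a range from 20 ug/mL to 100 ug/mL. The expected step is a 1.2-fold lower number from compound 1 to compound 3 (0.06 log units; within the scatter).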

Compound 3, half-maximal inhibitory concentration: 53.8 ug/mL
Compound 3: middle estimate off by 1.2-fold (0.08 log units), on the low side, within the range that was stated.
By their numbers in this assay, from the lowest: compounds 2, 1 and 3 (each within the scatter of the next).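

In this assay, methoxy in place of hydrogen on an aromatic carbon, para to a large group, gives a 1.0-fold higher number from compound 1 to compound 3 (0.01 log units; within the scatter), so this small addition to the phenyl of compound 1 produces no step beyond the scatter. The swap of 3,4-dihydroxyphenyl for 4-methoxyphenyl gives a 1.8-fold higher number from compound 2 to compound 3 (0.26 log units; within the scatter), which also stays within the scatter, so the three groups tried on this ring cannot be told apart in this assay. No evidence is available that bears on these results.

As far as these compounds go, whether an amine, a carboxylic acid or a longer chain at the same place would give a step beyond the scatter remains open. Also open, from the compounds shown here alone, is whether the methoxy change would read the same way on a core other than that of compound 1.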